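Aryl hydrazone series: an aminophenyl variant awaits measurement

A few compounds are considered here, and "the series" means these few. Any claim that something is new, unique, unknown or untested is made for them only; others in the source may bear on it.

Compound 1 `Cc1ccc(C(=O)N/N=C/C2=C(Cl)c3ccccc3CCC2)cc1` is the stronger of the two measured hydrazones: in a functional assay on HeLa cells (Homo sapiens) for inhibition, read by sulforhodamine B assay, with a stated time of 48 h (on this read-out higher numbers stand for weaker inhibition of growth and lower numbers for stronger inhibition of growth), compound 1 gives 300 nM, whereas compound 2 `COc1cccc(C(=O)N/N=C/C2=C(Cl)c3ccccc3CCC2)c1C` gives 9200 nM, a gap well beyond the scatter. Compound 3 `Nc1ccccc1C(=O)N/N=C/C1=C(Cl)c2ccccc2CCC1` differs from compound 1 by 2-aminophenyl in place of 4-methylphenyl on a carbonyl carbon, on a carbonyl carbon whose other neighbour is an amide-type nitrogen. Going by the values given here, no single-point step between measured compounds is available to anchor this change, so the expectation is uncertain. Compound 3 is expected to lose some potency, a step of a 5.0-fold higher number from compound 1 to compound 3 (0.70 log units; beyond the scatter), giving an estimated 1500 nM in this assay, within 300 nM to 8000 nM.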

Compound 3, concentration for 50% growth inhibition: > 100000 nM
Compound 3 was reported as a limit; the forecaster's own chance of this, stated with the estimate: 5%; middle value at least 66-fold (1.82 log units) from the limit.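

Going by these compounds alone, putting 2-aminophenyl in place of 4-methylphenyl on a carbonyl carbon is the first change in one place, and in this assay it gives an at least 330-fold higher number from compound 1 to compound 3 (2.52 log units; beyond the scatter). The value of compound 3 is a limit of the assay and not a number: the limit of > 100000 nM in this assay, at which 1 of the 3 values shown sits. The two groups share the same heavy-atom count and one six-membered aromatic ring, so these counts alone do not decide the outcome at this position. The compounds shown leave open whether the amine or its place on the ring accounts for the loss; 4-aminophenyl and 2-methylphenyl would separate the two.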